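A few compounds are considered here, and "the series" means these few. Any claim that something is new, unique, unknown or untested is made for them only; others in the source may bear on it.

Going by the values given here, in an ADME assay on MT4 cells (Homo sapiens) for cytotoxicity, read by MTT assay, with a stated time of 5 days (on this read-out higher numbers stand for lower toxicity in this test and lower numbers for higher toxicity in this test), compound 1 `Cc1cccc(C)c1Oc1cc(Nc2ccc(C#N)cc2)[nH]c(=O)c1Br` gives 63000 nM, the higher of the two numbers so far, while compound 2 `Cc1cc(C)cc(Oc2cc(Nc3ccc(C#N)cc3)[nH]c(=O)c2Br)c1` gives 19000 nM. Compound 3 `Cc1cccc(C)c1Oc1cc(Nc2ccc(C#N)cc2)[nH]c(=O)c1` has not been measured. It differs from compound 1 by hydrogen in place of bromo on an aromatic carbon, with hydrogen in place of bromo on an aromatic carbon. Among the compounds with values here, the only measured step, a 3.3-fold lower number from compound 1 to compound 2 (0.52 log units; beyond the scatter), leaves the bromo untouched, so it offers only a rough sense of how far these numbers can move. No change beyond the scatter is therefore expected, and the estimated step is a 1.3-fold lower number from compound 1 to compound 3 (0.10 log units; within the scatter). For compound 3, the estimated value is 50000 nM, with an expected range of 18000 nM to 130000 nM.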

Compound 3, half-maximal cytotoxic concentration: 36000 nM
Compound 3: middle estimate off by 1.4-fold (0.14 log units), on the high side; low and high end bracket the measured number.
By their numbers in this assay, from the lowest: compounds 2, 3 and 1 (each within the scatter of the next, the first and the last beyond it).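

With hydrogen in place of bromo on the aromatic carbon, this assay gives a 1.8-fold lower number from compound 1 to compound 3 (0.24 log units; within the scatter) and so, unlike the swap on the oxygen-linked dimethylphenyl ring, this change stays inside the usual scatter. At this position the bromo is therefore not needed to keep the number of compound 1 within that scatter. No evidence is at hand to explain this result. As far as these compounds go, whether a methyl, an amine or a carboxylic acid at this position would move the number beyond the scatter stays open. So does whether hydrogen in place of bromo would give a similar step with the 3,5-dimethylphenyl group of compound 2.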